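Working notes: permeability readings in a three-compound series

The source may report more compounds than this note shows. Statements on the series, on what has been measured and on what is new or still open speak of the compounds shown alone.

Measured so far:
- compound 1, `c1ccc(-c2ccc3c(NCCCNCc4ccco4)ccnc3c2)cc1`: in an ADME assay for permeability, using PAMPA, with a stated time of 30 min, at pH 7.4 (a lower number here means that the compound crosses the layer more slowly, a higher number that the compound crosses the layer faster), compound 1 gives 237 10^-6 cm/s
- compound 2, `COc1ccc(F)cc1CNCCCNc1ccnc2cc(C3CCCCC3)ccc12`: in this assay compound 2 gives 23 10^-6 cm/s
- compound 3, `COc1cccc(CNCCCNc2ccnc3cc(CCC(C)C)ccc23)c1O`: in this assay compound 3 gives 23 10^-6 cm/s

Compound 2 sits at the low end of the three numbers. It is level with compound 3 at the digits recorded, the two values falling within the scatter of each other, so no order between compound 2 and compound 3 can be read. Compound 1, the furthest from compound 2, gives a higher number, and that gap lies beyond the scatter. Among the measured compounds shown here, none of these three pairs differs in a single place, so no single-change step can be drawn among them.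

The next compound, compound 4, `COc1ccc(F)cc1CNCCCNc1ccnc2cc(CC(C)C)ccc12`, differs from compound 2 in one place: isobutyl in place of cyclohexyl on an aromatic carbon. Both groups are carbon-only and carry no hydrogen-bond donors or acceptors, and the attachment point on the shared core is unchanged.

For the measured compounds named here, with no measured step of comparable kind in hand, the expected step in this assay from compound 2 to compound 4 is small, a 1.1-fold higher number from compound 2 to compound 4 (0.04 log units; within the scatter), and is not expected to exceed the scatter in either direction. For compound 4 the estimated apparent permeability is 25 10^-6 cm/s, with a range from 10 10^-6 cm/s to 60 10^-6 cm/s.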

Compound 4, apparent permeability: 23 10^-6 cm/s
Compound 4: middle estimate off by 1.1-fold (0.04 log units), on the high side; the measured number falls inside the stated range.
By their numbers in this assay, from the lowest: compounds 2, 3 and 4 (each within the scatter of the next); then compound 1.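

Among the compounds shown here, replacing cyclohexyl with isobutyl on this aromatic carbon gives, in this assay, no change at the digits printed from compound 2 to compound 4 (within the scatter), and this is the only single-place step so far. The earlier compounds shown here each differed in more than one place and could not isolate this position, whereas this pair shows that, for these two groups, removing the six-membered non-aromatic ring of carbon only and moving to an open, branched carbon group leaves the reading within the scatter. No measured evidence is available to explain this outcome.

For the compounds shown here, the step covers only two carbon-only groups with no hydrogen-bond donors or acceptors, so it remains open whether a group such as an amine, a carboxylic acid or a longer chain on the same aromatic carbon would leave the reading equally unmoved. Going by these compounds alone, no single-place step yet connects compound 1, at 237 10^-6 cm/s, to the other compounds, so which of its structural features goes with that reading also remains open.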